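The source may hold more compounds than are shown below. What is called first, only, known or untested is meant among the compounds shown, and "the series" means these compounds.

Measured in an ADME assay on HaCaT cells (Homo sapiens) for inhibition, read by sulforhodamine B assay, with a stated time of 48 h; a lower number here means a stronger inhibitor of growth, a higher number a weaker inhibitor of growth:
compound 1 `CC(C)(C)NCc1c(C(=O)O)nn(-c2ccccc2)c1-c1ccc(Br)cc1` gives 366000 nM
compound 2 `Cc1ccc(-c2c(CNC(C)(C)C)c(C(=O)O)nn2-c2ccccc2)cc1` gives > 688000 nM (a limit)
compound 3 `CC(C)(C)NCc1c(C(=O)O)nn(-c2ccccc2)c1-c1ccc([N+](=O)[O-])cc1` gives > 634000 nM (a limit)

Compound 3 stands only at a limit: compound 3 reads > 634000 nM in this assay, which is a limit and not a number. Compound 2 is also reported only as a limit, so compound 1 alone carries a number.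

Compound 4 `CC(C)(C)NCc1c(C(=O)O)nn(-c2ccc(Cl)cc2)c1-c1ccc([N+](=O)[O-])cc1` differs from compound 3 by chloro in place of hydrogen on an aromatic carbon in one place: phenyl to 4-chlorophenyl, with chloro in place of hydrogen on an aromatic carbon.

Going by the values given here, no measured step makes this change. Among the compounds with values here, the steps that bear on it only indirectly exchange groups elsewhere on the molecule. Of these, an at least 1.8-fold higher number from compound 1 to compound 2 (0.27 log units; that floor lies within the scatter) and an at least 1.7-fold higher number from compound 1 to compound 3 (0.23 log units; that floor lies within the scatter) both have floors within the scatter, while a step that the two limits leave unreadable from compound 2 to compound 3 has no readable size.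

These notes therefore expect no step beyond the scatter in this assay and assign no firm direction. A further limit is as likely a report as a number. The expected result is an at least 1.2-fold lower number from compound 3 to compound 4 (0.10 log units; that floor lies within the scatter) as the estimated step. For compound 4 the estimated value is 500000 nM, with an expected range of 250000 nM to 900000 nM.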

Compound 4, concentration for 50% growth inhibition: > 583000 nM
Compound 4 ended at the assay's limit; the forecaster's own chance of this, stated with the estimate: 60%; at least 1.1-fold (0.06 log units) between middle value and limit.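

In this assay compound 4 reads > 583000 nM, a limit and not a number. Compound 3 also stands only at a limit, so no step can be read from compound 3 to compound 4. The compounds shown leave open whether phenyl to 4-chlorophenyl changes growth inhibition at all, and in which direction.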